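The compounds below may be only part of what the source reports. "The series", "measured", "known", "first", "only" and "open" are said of these compounds alone.

Measured so far:
Compound 1, `O=C(/C=C/c1ccc2c(c1)B(O)OC2)c1cccs1`: 10400 nM
Compound 2, `CSc1ccc(C(=O)/C=C/c2ccc3c(c2)B(O)OC3)cc1`: 4100 nM

Both numbers come from a functional assay on SK-OV-3 cells (Homo sapiens) for cytotoxicity, read by MTT assay, with a stated time of 48 h; on this read-out higher numbers stand for weaker inhibition and lower numbers for stronger inhibition. For the measured compounds named here, compound 2 holds the lower of the two; the only other number, that of compound 1, lies higher by a gap beyond the usual scatter of repeated measurements, so compound 2 is the stronger inhibitor of this pair. Compound 3, `Nc1ccc(C(=O)/C=C/c2ccc3c(c2)B(O)OC3)cc1`, has not yet been measured in this assay. It differs from compound 2 in one place: amino in place of methylsulfanyl on an aromatic carbon. Going by the values given here, no measured pair shows this particular change, so its effect has not been observed directly. In this assay the step of a 1.5-fold higher number from compound 2 to compound 3 (0.17 log units; within the scatter) is expected to be small, leaning toward a higher number, and may well stay within the scatter. Compound 3 is therefore estimated at 6000 nM, with a range from 2000 nM to 18000 nM.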

Compound 3, half-maximal inhibitory concentration: 20200 nM
Compound 3: the middle estimate sits 3.4-fold (0.53 log units) below what was measured; measured number above the stated range.
By their numbers in this assay, from the lowest: compound 2; then compounds 1 and 3 (each within the scatter of the next).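

In this assay the swap of methylsulfanyl for amino, on an aromatic carbon para to a large group, gives a 4.9-fold higher number from compound 2 to compound 3 (0.69 log units; beyond the scatter) and so shows that this position is sensitive to the group it carries, with amino the weaker of these two. Exchanging the whole thiophen-2-yl on the carbonyl carbon for 4-aminophenyl gives a 1.9-fold higher number from compound 1 to compound 3 (0.29 log units; within the scatter) and stays within the scatter, so compound 1 and compound 3 cannot be told apart here. Nothing shown here explains why the swap at this position matters.

A single pair cannot tell which part of methylsulfanyl carries the difference, the sulfur or the methyl. Methoxy, methyl or dimethylamino at the same place could separate these possibilities, and whether any of them matches methylsulfanyl remains an open question.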